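A 4-Chlorobenzyl Group Enters the Core of Compound 3

The compounds below may be only part of what the source reports. "The series", "measured", "known", "first", "only" and "open" are said of these compounds alone.

Compound 1, `Cc1c(Cc2ccccc2)c(=O)oc2cc(OCC(O)CNCc3ccccc3)ccc12`, in an ADME assay on A549 cells (Homo sapiens) for cytotoxicity, read by CellTiter-Glo (a higher number here means that more compound is tolerated, a lower number that less compound is tolerated), gives the limit > 100000 nM.
Compound 2, `Cc1c(Cc2ccccc2)c(=O)oc2cc(OCC(O)CNc3nccs3)ccc12`, in this assay gives 93000 nM.
Compound 3, `Cc1cc(=O)oc2cc(OCC(O)CN3CCC(C(N)=O)CC3)ccc12`, in this assay gives the limit > 100000 nM.

Compound 3 stands at a limit of the assay, not at a number: its reading is the limit of > 100000 nM in this assay, at which 2 of the 3 values shown sit. Compound 4, `Cc1c(Cc2ccc(Cl)cc2)c(=O)oc2cc(OCC(O)CN3CCC(C(N)=O)CC3)ccc12`, differs from it by 4-chlorobenzyl in place of hydrogen on an aromatic carbon. Within the data shown here, no measured step touches this place; the only measured step, an at least 1.0-fold lower number from compound 1 to compound 2 (0.03 log units; that floor lies within the scatter), changes the amine substituent instead. Compounds 1 and 2 both carry a benzyl at this place, and their values are shown above. On that basis the expected step for an at least 1.1-fold lower number from compound 3 to compound 4 (0.04 log units; that floor lies within the scatter) is none beyond the scatter. Compound 4 is therefore estimated at 90000 nM, within 40000 nM to 150000 nM.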

Compound 4, half-maximal cytotoxic concentration: 40000 nM
For compound 4 the middle estimate is 2.3-fold (0.35 log units) above the measured one, within the range that was stated.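

In this assay, 4-chlorobenzyl in place of hydrogen on an aromatic carbon gives an at least 2.5-fold lower number from compound 3 to compound 4 (0.39 log units; beyond the scatter). Among these compounds, this is the first measured step at this place, and it shows that a change here can lower the tolerated concentration beyond the scatter. The step remains a floor because compound 3 stands at a limit: the limit of > 100000 nM in this assay, at which 2 of the 4 values shown sit.

As far as these compounds go, what a plain benzyl, a methyl group or a carboxylic acid would give at this place, with the rest of compound 3 unchanged, remains open.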